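The source may hold more compounds than are shown below. What is called first, only, known or untested is meant among the compounds shown, and "the series" means these compounds.

Going by the values given here, compound 1 `COc1ccc(C2=NN(c3nc(-c4ccc(Br)cc4)cs3)C(c3cccs3)C2)cc1` is one of only two measured compounds in a functional assay on WM 266-4 cells (Homo sapiens) for antiproliferative activity, read by MTT assay, with a stated time of 48 h (on this read-out higher numbers stand for weaker inhibition and lower numbers for stronger inhibition), where compound 1 gives 5870 nM. The other, compound 2 `COc1ccc(C2=NN(c3nc(-c4ccc(C(F)(F)F)cc4)cs3)C(c3cccs3)C2)cc1`, differs by trifluoromethyl in place of bromo on an aromatic carbon, and in this assay compound 2 gives 8110 nM; the two numbers lie within the scatter of each other, so neither can be ranked above the other. The unmeasured compound 3 `Clc1ccc(C2=NN(c3nc(-c4ccc(Br)cc4)cs3)C(c3cccs3)C2)cc1` carries chloro in place of methoxy on an aromatic carbon, that is, 4-methoxyphenyl becomes 4-chlorophenyl. Among the compounds with values here, no measured step touches this position; the only step known, a 1.4-fold higher number from compound 1 to compound 2 (0.14 log units; within the scatter), concerns the other aryl ring and stayed within the scatter. With nothing pointing either way, the change from compound 1 to compound 3 is expected to give a 1.0-fold higher number from compound 1 to compound 3 (0.01 log units; within the scatter), no step beyond the scatter. Compound 3 is therefore estimated at 6000 nM, with a range of 2500 nM to 15000 nM.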

Compound 3, half-maximal inhibitory concentration: 1450 nM
For compound 3 the middle estimate is 4.1-fold (0.62 log units) above the measured one; the whole stated range lies above it.
By their numbers in this assay, from the lowest: compound 3; then compounds 1 and 2 (each within the scatter of the next).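

Going by these compounds alone, at the 4-methoxyphenyl position, this assay does respond to a single substitution: the change to 4-chlorophenyl gives a 4.0-fold lower number from compound 1 to compound 3 (0.61 log units; beyond the scatter) and so, unlike the only earlier step, which lay on the other aryl ring, it clears the scatter. This makes the aromatic carbon para to a large group the first place among the compounds shown where one change separates two compounds, although the size of the step is only modest. Nothing measured here accounts for the direction of this step.

From the compounds shown here alone, how an amine, a carboxylic acid or a longer chain such as ethoxy would read at this place stays open. Going by these compounds, it is also open whether the step from methoxy to chloro would carry over with trifluoromethyl in place of bromo on the other aryl ring.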